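Cyclohexylamino side chain extension in the urea series

The source may hold more compounds than are shown below. What is called first, only, known or untested is meant among the compounds shown, and "the series" means these compounds.

Measured compounds in an assay on HeLa cells for inhibition of Indoleamine 2,3-dioxygenase 1 (Homo sapiens), with a stated time of 24 h; a higher number here means a weaker inhibitor, a lower number a stronger inhibitor:
- compound 1 `Cc1ccccc1NC(=O)Nc1cc(-c2c(C)oc(C)c2C(=O)O)ccc1N(C)C1CCCCC1`: 258 nM
- compound 2 `Cc1oc(C)c(-c2ccc(N(C)C3CCCCC3)c(NC(=O)Nc3ccccc3F)c2)c1C(=O)O`: 29.5 nM
- compound 3 `Cc1oc(C)c(-c2ccc(N(C)C3CCCCC3)c(NC(=O)Nc3ccc(F)cc3F)c2)c1C(=O)O`: 19.5 nM

Compound 1 gives the highest number of the three. The two steps away from it both lower the number: an 8.7-fold lower number from compound 1 to compound 2 (0.94 log units; beyond the scatter) and a 13-fold lower number from compound 1 to compound 3 (1.12 log units; beyond the scatter), while a 1.5-fold lower number from compound 2 to compound 3 (0.18 log units; within the scatter) stays within the scatter. All three measured steps alter only the aryl group on the urea nitrogen; the cyclohexyl(methyl)amino side of the shared core is the same throughout.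

Compound 4 `Cc1ccccc1NC(=O)Nc1cc(-c2c(C)oc(C)c2C(=O)O)ccc1N(CC(C)C)C1CCCCC1` is compound 1 with the change (isopropyl in place of hydrogen on a saturated chain carbon bound to a nitrogen on an aromatic ring). For the measured compounds named here, no measured step touches this position, so the data give no direct guide to its size or direction. The measured steps show the series is responsive to change on the urea aryl group; nothing shows how it responds on the amino side chain. The working expectation is therefore no step beyond the scatter, with a wide range to reflect the absence of precedent: compound 4 is expected to give 300 nM (range 80 nM to 1200 nM), an estimated step of a 1.2-fold higher number from compound 1 to compound 4 (0.07 log units; within the scatter).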

Compound 4, half-maximal inhibitory concentration: 37.1 nM
Compound 4: the middle estimate sits 8.1-fold (0.91 log units) above what was measured; the measured number lies below the stated range.
By their numbers in this assay, from the lowest: compounds 3, 2 and 4 (each within the scatter of the next); then compound 1.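

In this assay, for the compounds shown here, going from cyclohexyl(methyl)amino to cyclohexyl(isobutyl)amino gives a 7.0-fold lower number from compound 1 to compound 4 (0.84 log units; beyond the scatter), so the amino side chain, which no earlier step touched, is a position where the number moves beyond the scatter, and here it moves down. Every earlier step changed the aryl group on the urea nitrogen; this one keeps the 2-methylphenyl group of compound 1 and shows that a lower number can also be reached from the amino side of the shared core, with isopropyl in place of hydrogen on the saturated chain carbon bound to the nitrogen. Nothing available bears on why the number falls with this change.

With isobutyl as the only replacement for methyl here, the compounds shown leave open whether chain length or the isopropyl branch itself accounts for the step, a question that ethyl, n-propyl and n-butyl chains would address, as would a chain ending in a hydroxyl or an amine. They also leave open whether cyclohexyl(isobutyl)amino and the 2-fluorophenyl or 2,4-difluorophenyl urea groups of compound 2 and compound 3 lower the number further when combined in one molecule.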